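From Ethoxycarbonyl to Carbamoyl on a Shared Core

The source may hold more compounds than are shown below. What is called first, only, known or untested is meant among the compounds shown, and "the series" means these compounds.

Measured in an ADME assay on L6 cells (Rattus norvegicus) for cytotoxicity, read by resazurin assay, with a stated time of 72 h; a lower number here means a stronger inhibitor, a higher number a weaker inhibitor:
- compound 1 `CN(C)C12CCNC(C(c3ccc(C(F)(F)F)cc3)C1)C(c1ccc(C(F)(F)F)cc1)C2` gives 9440 nM here
- compound 2 `CCOC(=O)CN1CCC2(N3CCCCC3)CC(c3ccc(Cl)cc3)C1C(c1ccc(Cl)cc1)C2` gives 13100 nM here

In this assay compound 1 gives 9440 nM and compound 2 gives 13100 nM, two numbers that lie within the usual scatter of each other. For the measured compounds named here, compound 2 therefore stands level with the only other measured compound. Compound 3 `NC(=O)CN1CCC2(N3CCCCC3)CC(c3ccc(Cl)cc3)C1C(c1ccc(Cl)cc1)C2` departs from compound 2 at one place, with amino in place of ethoxy on a carbonyl carbon. Going by the values given here, no two measured compounds differ at only one place, so the size of such a change has not been observed here. Starting from compound 2 at 13100 nM, a modest rise in the number is expected, meaning a somewhat weaker inhibitor, though the expected range also allows for no change beyond the scatter. The expected change is a 1.9-fold higher number from compound 2 to compound 3 (0.28 log units; within the scatter) in this measurement. For compound 3 the estimated value is 25000 nM, with an expected range from 9000 nM to 70000 nM in this assay.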

Compound 3, half-maximal inhibitory concentration: 23800 nM
For compound 3 the middle estimate is 1.1-fold (0.02 log units) above the measured one; the range from low to high includes it.
By their numbers in this assay, from the lowest: compounds 1, 2 and 3 (each within the scatter of the next, the first and the last beyond it).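

For the compounds shown here, this is the first pair that differs at only one place, and in this assay amino in place of ethoxy on a carbonyl carbon gives a 1.8-fold higher number from compound 2 to compound 3 (0.26 log units; within the scatter). At this place, on a carbonyl carbon whose other neighbour is a saturated chain carbon, going from ethoxycarbonyl to carbamoyl therefore does not move the reading beyond the scatter, even though the leaving ethoxy has 3 heavy atoms and the entering amino has 1 and brings a hydrogen-bond donor. The data offer no measured explanation for this step.

The compounds shown leave open whether a carboxylic acid, an N-methyl amide or a longer ester such as butoxycarbonyl at this place would also stay within the scatter. They also leave open what happens if the whole (ethoxycarbonyl)methyl group gives way to a plain methyl or a longer chain.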